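The source may report more compounds than this note shows. Statements on the series, on what has been measured and on what is new or still open speak of the compounds shown alone.

The compounds measured so far in an assay for inhibition of serine/threonine-protein kinase PLK3 (Homo sapiens), read by FRET and Z'-LYTE, with a stated time of 1 h; a lower number here means a stronger inhibitor, a higher number a weaker inhibitor:
compound 1 `CCC1C(=O)N(C)c2cnc(-n3ccc4cc(C(=O)NC)ccc43)nc2N1c1ccn(C)n1`: > 10000 nM
compound 2 `CC[C@@H]1C(=O)N(C)c2cnc(-n3ccc4ccccc43)nc2N1C1CCCC1`: > 20000 nM
compound 3 `CCC1C(=O)N(C)c2cnc(-n3ccc4cc(F)ccc43)nc2N1c1ccn(C)n1`: > 10000 nM

Compound 3 stands at a limit of this assay, and its value is not a number. For compound 1 the value given is likewise a limit. For compound 2 the value given is also a limit, so none of the three compounds offers a readable number.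

The next compound, compound 4 `CCCCNC(=O)c1ccc2c(ccn2-c2ncc3c(n2)N(c2ccn(C)n2)C(CC)C(=O)N3C)c1`, differs from compound 3 in one place: butylcarbamoyl in place of fluoro on an aromatic carbon. Among the measured compounds shown here, the only measured step that bears on this position is a step that the two limits leave unreadable from compound 1 to compound 3, where methylcarbamoyl and fluoro both leave the compound at a limit. Since both endpoints sit at the limit of > 10000 nM in this assay, at which 2 of the 3 values shown sit, the size of that step cannot be read, and the limit of > 20000 nM in this assay, at which 1 of the 3 values shown sits, adds nothing readable either. For the measured compounds named here, the data therefore give no expectation of a step in this assay in either direction, only that compound 4 is more likely than not to stay at a limit as well.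

Compound 4 is expected to give 15000 nM, within a range from 3000 nM to 100000 nM. This amounts to an expected step that the limit leaves unreadable from compound 3 to compound 4.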

Compound 4, half-maximal inhibitory concentration: > 10000 nM
Compound 4: only a limit was reported; the forecaster's own chance of this, stated with the estimate: 80%; the middle value is on the limit's open side.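

In this assay compound 4 gives > 10000 nM, which is a limit and not a number. Compound 1 and compound 3 stand at limits as well, and neither step to compound 4 can be read: the limit of > 10000 nM in this assay, at which 3 of the 4 values shown sit. The compounds shown leave open whether any group on this aromatic carbon changes the inhibition of the kinase at all.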